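A few compounds are considered here, and "the series" means these few. Any claim that something is new, unique, unknown or untested is made for them only; others in the source may bear on it.

Measured so far in a functional assay on CHO cells for positive allosteric modulation of metabotropic glutamate receptor 2 (Homo sapiens), read by scintillation counting and GTPgammaS binding, with a stated time of 30 min; on this read-out lower numbers stand for an effect already at smaller amounts and higher numbers for an effect only at larger amounts of compound:

compound 1, `COc1ccc(-c2ccn(CCC(C)C)c(=O)c2C#N)cc1F`: 1170 nM
compound 2, `COc1ccc(-c2ccn(CCC(C)C)c(=O)c2C#N)cc1Cl`: 363 nM
compound 3, `CCCCn1ccc(-c2ccc(Oc3ccnc(C)c3)cc2Cl)c(C#N)c1=O`: 933 nM

Compound 2 and compound 1 share a core and differ in one place: fluoro in place of chloro on an aromatic carbon. Along that change the number rose, a 3.2-fold higher number from compound 2 to compound 1 (0.51 log units; beyond the scatter), a step beyond the scatter.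

Compound 3 stands on another core; how its core differs from that of compound 2 is not broken down here. Its value in this assay sits close to compound 1, within the scatter, and is beyond the scatter from compound 2.

Compound 4, `CCCCn1ccc(-c2ccc(Oc3ccnc(C)c3)cc2F)c(C#N)c1=O`, is unmeasured. It relates to compound 3 as compound 1 does to compound 2: fluoro in place of chloro on an aromatic carbon. The surroundings are not identical, though: in compound 2 the changed carbon is ortho to a methoxy group and meta to a large group, whereas in compound 3 it is ortho to a large group and meta to a (2-methylpyridin-4-yl)oxy group. It is therefore the same kind of change, not the same change.

On that basis a rise of similar size is expected, a 2.7-fold higher number from compound 3 to compound 4 (0.43 log units; beyond the scatter), resting on the step of a 3.2-fold higher number from compound 2 to compound 1 (0.51 log units; beyond the scatter). Compound 4 is estimated at 2500 nM.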

Compound 4, half-maximal effective concentration: 390 nM
Compound 4: the middle estimate sits 6.4-fold (0.81 log units) above what was measured; measured number outside the range, below it.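

In this assay fluoro in place of chloro brought a 2.4-fold lower number from compound 3 to compound 4 (0.38 log units; beyond the scatter) on the core of compound 3, the opposite direction to the earlier step. So in this series, the same exchange on an aromatic carbon did not keep its direction or its size when carried from one core to the other: the same change on two cores in this assay, a 3.2-fold higher number (0.51 log units; beyond the scatter) from compound 2 to compound 1 and a 2.4-fold lower number (0.38 log units; beyond the scatter) from compound 3 to compound 4, 7.7-fold (0.89 log units) apart, beyond the scatter of two such steps. Going by these compounds alone, this shows that a step read on one of these cores is a poor guide to the other, but with only two pairs it does not show which difference between the cores matters, or which way the step would go on a third core.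

The compounds shown carry only chloro or fluoro at the changed carbon, so it remains open how hydrogen, methyl or trifluoromethyl there would read on either core. As far as these compounds go, it is also open whether exchanging methoxy for the (2-methylpyridin-4-yl)oxy group, with all else kept, would be enough to turn the step around.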